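The source may report more compounds than this note shows. Statements on the series, on what has been measured and on what is new or still open speak of the compounds shown alone.

Going by the values given here, compound 1 `CSc1ccc(CNc2nc(SC)nc3ncccc23)cc1` is the one member of this set with a measured number: in a functional assay on MCF7 cells (Homo sapiens) for cytotoxicity, read by MTT assay, with a stated time of 72 h (a higher number here means that more compound is tolerated, a lower number that less compound is tolerated), compound 1 gives 9130 nM. Compound 3 `CSc1ccc(CNc2nc([SeH])nc3ccccc23)cc1` is built on a different core, and the difference between the two cores is not broken down here. In this assay compound 3 reaches only a limit of the assay, > 100000 nM. Compound 2 `COc1ccc(CNc2nc([SeH])nc3ccccc23)cc1` differs from compound 3 in one place, (methoxy in place of methylsulfanyl on an aromatic carbon). In this assay compound 2 likewise sits at a limit of the assay, > 100000 nM. The step that the two limits leave unreadable from compound 3 to compound 2 therefore cannot be read in size, because the limit of > 100000 nM in this assay, at which 2 of the 3 values shown sit, covers both ends of it.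

Compound 4 `COc1ccc(CNc2nc(SC)nc3ncccc23)cc1` is the not-yet-measured partner of compound 1, and it carries the same change, (methoxy in place of methylsulfanyl on an aromatic carbon). Among the compounds with values here, the one earlier instance of this change gives no readable size, so the expectation for compound 4 rests mainly on compound 1 itself and on its value 9130 nM, with a step no larger than the scatter: in this assay compound 4 is expected to give 12000 nM, between 4000 nM and 40000 nM, which is an expected step of a 1.3-fold higher number from compound 1 to compound 4 (0.12 log units; within the scatter).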

Compound 4, concentration lethal to 50% of the cells: > 100000 nM
Compound 4: only a limit was reported; the forecaster's own chance of this, stated with the estimate: 10%; at least 8.3-fold (0.92 log units) between middle value and limit.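

Going by these compounds alone, on the core of compound 1, putting methoxy in place of methylsulfanyl on an aromatic carbon gives in this assay an at least 10-fold higher number from compound 1 to compound 4 (1.03 log units; beyond the scatter), so on this core the change is large and removes the only measured cell-killing value in the set. Compound 4 reaches only a limit of the assay, > 100000 nM, which means this step gives a lower bound on the size and not an exact size. The same change on the other core, from compound 3 to compound 2, cannot be read, so the two cores agree only in that their methoxy compounds sit at the limit, and whether the step has the same size on both stays unknown, because the values crowd at one end of the range: the limit of > 100000 nM in this assay, at which 3 of the 4 values shown sit.

Within the data shown here, with compound 1 as the only compound with a number, it remains open whether the methylsulfanyl group itself is needed for a measurable value on this core. An ethylsulfanyl group, a longer chain or an amine on that same aromatic carbon would show how narrow this requirement is.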